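From a Ring Amide to a Cyclopropyl Amide

A few compounds are considered here, and "the series" means these few. Any claim that something is new, unique, unknown or untested is made for them only; others in the source may bear on it.

Compound 1 `Nc1sc(-c2ccc(Cl)cc2)c(-c2ccc(Cl)cc2)c1C(=O)N1CCCCC1=O` gives 1820 nM in a functional assay on A549 cells (Homo sapiens) for inhibition, read by sulforhodamine B assay, with a stated time of 72 h; a higher number here means a weaker inhibitor, a lower number a stronger inhibitor.
Compound 2 `CCOC(=O)Nc1sc(-c2ccc(Cl)cc2)c(-c2ccc(Cl)cc2)c1C(=O)NC1CC1` gives 39800 nM in this assay.
Compound 3 `CN1CCN(C(=O)c2c(N)sc(-c3ccc(Cl)cc3)c2-c2ccc(Cl)cc2)CC1` gives 590 nM in this assay.

Among the three measured compounds, compound 1 stands second highest in this assay. Among the compounds with values here, its nearest neighbour is compound 3, reached by the single step of a 3.1-fold lower number from compound 1 to compound 3 (0.49 log units; beyond the scatter), a modest change and the only step between compounds that differ in one place. Within the data shown here, compound 2 lies far from compound 1 on the high side, but no single-place step connects them.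

Compound 4 `Nc1sc(-c2ccc(Cl)cc2)c(-c2ccc(Cl)cc2)c1C(=O)NC1CC1` is made from compound 1 by the change (cyclopropylamino in place of 2-oxopiperidin-1-yl on a carbonyl carbon). Among the measured compounds shown here, no measured step bears directly on this change. The step to compound 3 shows that swapping the group on the carbonyl carbon can move the number modestly, while compound 2 carries a cyclopropylcarbamoyl together with a further change on the amine and gives a much higher number, so it offers no clean comparison. Compound 4 is therefore expected to stay near compound 1, with a step of a 1.6-fold higher number from compound 1 to compound 4 (0.22 log units; within the scatter) that may not exceed the scatter. The estimate for compound 4 is 3000 nM, within a range from 800 nM to 12000 nM.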

Compound 4, half-maximal inhibitory concentration: 1950 nM
The estimate for compound 4 lay 1.5-fold (0.19 log units) above the measured number; measured number inside the range.
By their numbers in this assay, from the lowest: compound 3; then compounds 1 and 4 (each within the scatter of the next); then compound 2.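

In this assay, a 1.1-fold higher number from compound 1 to compound 4 (0.03 log units; within the scatter) shows that on this carbonyl carbon cyclopropylamino can stand in place of 2-oxopiperidin-1-yl with the two compounds remaining level, even though the change removes the six-membered ring and brings in a hydrogen-bond donor. Among the three groups seen at this place, only 4-methylpiperazin-1-yl stands apart, as a 3.3-fold higher number from compound 3 to compound 4 (0.52 log units; beyond the scatter) confirms from the side of the new compound. Within the data shown here, compound 4 also gives the first clean reading of the other substituted place, since a 20-fold lower number from compound 2 to compound 4 (1.31 log units; beyond the scatter) isolates hydrogen in place of ethoxycarbonyl on a nitrogen on an aromatic ring and ties the large gap to that change, with cyclopropylamino held constant.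

Nothing presented here gives a measured reason for any of these steps. As far as these compounds go, it remains open whether morpholin-4-yl or dimethylamino on the carbonyl carbon would track compound 3 or compound 4, and whether a smaller acetyl on the nitrogen would carry the same penalty as ethoxycarbonyl.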